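The source may hold more compounds than are shown below. What is called first, only, known or untested is meant among the compounds shown, and "the series" means these compounds.

Of the compounds shown here, three built on one shared core have been tested in a functional assay on CHO cells for agonist activity at prostaglandin E2 receptor EP4 subtype (Rattus norvegicus), read by cAMP accumulation and immunoassay, with a stated time of 10 min; a lower number here means that less compound is needed, a higher number that more compound is needed for the effect. Compound 1 `O=C(O)CCCSCCN1C(=O)CC[C@@H]1/C=C/[C@@H](O)Cc1cccc(-c2ccc3[nH]ccc3c2)c1` gives 85 nM. Within the data shown here, compound 2 `O=C(O)CCCSCCN1C(=O)CC[C@@H]1/C=C/[C@@H](O)Cc1cccc(-c2nc3ccccc3s2)c1` gives 3.2 nM, and the single change between these two, a 27-fold lower number from compound 1 to compound 2 (1.42 log units; beyond the scatter), is the only step so far that can be read on its own. Compound 3 `O=C(O)c1csc(SCCN2C(=O)CC[C@@H]2/C=C/[C@@H](O)Cc2cccc(-c3ccccc3)c2)n1` gives 8 nM, which places it between the other two: its number is higher than that of compound 2 and lower than that of compound 1, both gaps lying beyond the usual scatter.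

Compound 4 `O=C(O)c1csc(SCCN2C(=O)CC[C@@H]2/C=C/[C@@H](O)Cc2cccc(-c3ccc(Cl)cc3)c2)n1` has not yet been measured. It differs from compound 3 by chloro in place of hydrogen on an aromatic carbon. Among the measured compounds shown here, no measured step touches this part of the molecule; the one known step swaps a whole ring system elsewhere on the same phenyl ring, so it offers little guidance for a single small substituent. A step within the scatter is therefore expected, no change at the digits printed from compound 3 to compound 4 (within the scatter), in either direction. Compound 4 is estimated at 8 nM, with a range from 3 nM to 20 nM.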

Compound 4, half-maximal effective concentration: 27 nM
The estimate for compound 4 lay 3.4-fold (0.53 log units) below the measured number, outside the stated range (above it).
By their numbers in this assay, from the lowest: compound 2; then compound 3; then compound 4; then compound 1.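

In this assay, adding a single chlorine gives a 3.4-fold higher number from compound 3 to compound 4 (0.53 log units; beyond the scatter), so this spot on the ring, para to a large group, responds even to one added atom. Among these compounds, the earlier compounds showed only what happens when a whole ring system is exchanged; this step is the first reading of a small substituent, and here, going from phenyl to 4-chlorophenyl, more compound is needed for the effect. No measurement at hand says why the number rises with this change.

From the compounds shown here alone, whether a fluoro group, a methoxy group or an amine at this same place would also raise the number remains open. So does whether chloro would have a similar effect on a compound with the side chain of compound 1 and compound 2.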